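A small side-chain extension from compound 3

The compounds below may be only part of what the source reports. "The series", "measured", "known", "first", "only" and "open" are said of these compounds alone.

In a functional assay on HCT-116 cells (Homo sapiens) for cytotoxicity (on this read-out higher numbers stand for weaker inhibition and lower numbers for stronger inhibition), compound 1 `COc1cc(N2CCNCC2)ccc1Nc1nc(NC2CCCCC2)c2nc[nH]c2n1` gives 88 nM and compound 2 `COc1cc(N2CCN(C(=O)N3CCC(O)C3)CC2)ccc1Nc1nc(NC2CCCCC2)c2nc[nH]c2n1` gives 27 nM as the lowest number of the set. Compound 3 `COc1cc(N2CCC(C(=O)N3CCC(N(C)C)C3)CC2)ccc1Nc1nc(NC2CCCCC2)c2nc[nH]c2n1` gives 58 nM and so lies within the scatter of compound 1, while compound 2 shows the lower number by a margin beyond the scatter.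

Compound 4 `COc1cc(N2CCC(CC(=O)N3CCC(N(C)C)C3)CC2)ccc1Nc1nc(NC2CCCCC2)c2nc[nH]c2n1` differs from compound 3 in one place ((3-(dimethylamino)pyrrolidin-1-yl)carbonyl)methyl in place of (3-(dimethylamino)pyrrolidin-1-yl)carbonyl on a saturated ring carbon with ((3-(dimethylamino)pyrrolidin-1-yl)carbonyl)methyl in place of (3-(dimethylamino)pyrrolidin-1-yl)carbonyl on a saturated ring carbon. Among the measured compounds shown here, the only measured step is a 3.3-fold lower number from compound 1 to compound 2 (0.51 log units; beyond the scatter) and it is modest. That step, however, places (3-hydroxypyrrolidin-1-yl)carbonyl on an amine nitrogen in a ring, so it offers only an indirect guide to a change on a saturated ring carbon. For the measured compounds named here, no measured pair tests the present change directly, and the data give no firm direction for it. A shift beyond the scatter is therefore not expected, and the estimated move in this assay is a 1.1-fold lower number from compound 3 to compound 4 (0.02 log units; within the scatter) and remains within the scatter. The estimate for compound 4 is 55 nM with 22 nM to 130 nM as its expected range.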

Compound 4, half-maximal inhibitory concentration: 59 nM
The estimate for compound 4 lay 1.1-fold (0.03 log units) below the measured number, and the stated range covers the measured number.
By their numbers in this assay, from the lowest: compound 2; then compounds 3, 4 and 1 (each within the scatter of the next).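

In this assay, ((3-(dimethylamino)pyrrolidin-1-yl)carbonyl)methyl in place of (3-(dimethylamino)pyrrolidin-1-yl)carbonyl gives a 1.0-fold higher number from compound 3 to compound 4 (0.01 log units; within the scatter) on a saturated ring carbon of a six-membered non-aromatic ring with 1 nitrogen. Among the compounds shown here, this is the only measured step at this carbon, as the earlier step was made on an amine nitrogen in a ring, and it shows that the read-out tolerates the added methyl link between this ring carbon and the carbonyl, with both compounds keeping the same 3-(dimethylamino)pyrrolidin-1-yl amide and the same counts of hydrogen-bond donors and acceptors in the group. The data shown offer no measurement that would explain this outcome.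

A single step cannot say whether a longer chain between this ring carbon and the carbonyl would also stay within the scatter, or whether the same holds once the amide is replaced by a simple amine or a carboxylic acid. For the compounds shown here, it also remains open how a 3-hydroxypyrrolidin-1-yl amide would read at this carbon, since that group has been seen only on the ring nitrogen of compound 2.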